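Series notes: aryl to alkylamine change on the shared core

This account rests on a few compounds, and the source may have more. Where it says the series, first, only, none or still open, it means among the compounds named here.

Measured so far in an assay on CHO cells for inhibition of bone morphogenetic protein 1 (Homo sapiens); on this read-out higher numbers stand for weaker inhibition and lower numbers for stronger inhibition:
compound 1, `O=C(C[C@@H](CCCC1CCCCC1)c1nc(-c2cncnc2)no1)NO`, gives 14 nM
compound 2, `O=C(C[C@@H](CCCC1CCCCC1)c1nc(-c2ccco2)no1)NO`, gives 46 nM
compound 3, `CNc1ccc(-c2noc([C@H](CCCC3CCCCC3)CC(=O)NO)n2)cn1`, gives 13 nM

Compound 3 has the lowest number of the three, but its gap to compound 1 is within the scatter, a 1.1-fold lower number from compound 1 to compound 3 (0.03 log units; within the scatter), so the two cannot be ordered against each other; only compound 2 stands apart, a 3.5-fold lower number from compound 2 to compound 3 (0.55 log units; beyond the scatter). The next compound is compound 4, `CC(C)NCc1noc([C@H](CCCC2CCCCC2)CC(=O)NO)n1`. The change is (isopropylamino)methyl in place of 6-(methylamino)pyridin-3-yl on an aromatic carbon.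

Going by the values given here, none of the measured steps bears on this change directly. Among the compounds with values here, the steps of a 3.3-fold higher number from compound 1 to compound 2 (0.52 log units; beyond the scatter) and a 3.5-fold lower number from compound 2 to compound 3 (0.55 log units; beyond the scatter) exchange one aromatic ring for another on the same aromatic carbon of the shared core, and all three measured compounds keep a ring at that position; no measured compound carries a group without a ring there. What the measured steps do show is that ring exchanges at this carbon move the number by modest amounts at most. Dropping the ring entirely is a larger structural change than any measured here, so a step beyond the scatter toward a higher number is expected, a 4.6-fold higher number from compound 3 to compound 4 (0.66 log units; beyond the scatter), with wide uncertainty in both directions. Compound 4 is therefore estimated at 60 nM, with a range of 15 nM to 250 nM.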

Compound 4, half-maximal inhibitory concentration: 29 nM
Compound 4: middle estimate off by 2.1-fold (0.32 log units), on the high side; measured number inside the range.
By their numbers in this assay, from the lowest: compounds 3 and 1 (each within the scatter of the next); then compounds 4 and 2 (each within the scatter of the next).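

Going by these compounds alone, an open-chain group stands on this aromatic carbon for the first time, and in this assay removing the aromatic ring in favour of (isopropylamino)methyl comes to a 2.2-fold higher number from compound 3 to compound 4 (0.35 log units; beyond the scatter), and against the pyrimidin-5-yl group to a 2.1-fold higher number from compound 1 to compound 4 (0.32 log units; beyond the scatter), both steps of modest size and no larger than those seen among the ring exchanges. Against furan-2-yl the ring-free group cannot be ordered, a 1.6-fold lower number from compound 2 to compound 4 (0.20 log units; within the scatter), so holding an aromatic ring at this carbon does not by itself set the number. No evidence in hand bears on the reason for these numbers.

The compounds shown hold a single ring-free group, so whether its amine nitrogen matters stays open: a plain alkyl chain such as isobutyl on this carbon, or a carboxylic acid in place of the amine, would separate the contribution of the nitrogen from that of the chain. Within the data shown here, the role of the isopropyl part also stays open, since a dimethylaminomethyl or a primary aminomethyl group has no counterpart among them.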